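This account rests on a few compounds, and the source may have more. Where it says the series, first, only, none or still open, it means among the compounds named here.

Compound 1 `CCCCCCCCCCCCCCCCOP(=O)(O)OCCSC(=S)N1CCCCC1`: 100000 nM in a functional assay on MDA-MB-231 cells (Homo sapiens) for inhibition, read by MTT assay, with stated times of 18 h and 4 h; a higher number here means a weaker inhibitor, a lower number a stronger inhibitor
Compound 2 `CCCOP(=O)(O)OCCSC(=S)N1CCCC1`: 67000 nM in this assay
Compound 3 `CCCCCCOP(=O)(O)OCCSC(=S)N1CCCCC1`: 85000 nM in this assay

All three measured compounds share the same core and differ only in the length of the alkyl chain on the phosphate and in the size of the saturated nitrogen ring. Compound 2 gives 67000 nM in this assay, and this number sits within the scatter of both compound 3 and compound 1, so no ordering among the three can be drawn from these data.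

Compound 4 `CCCCCCCCOP(=O)(O)OCCSC(=S)N1CCCC1` is compound 2 with pentyl in place of hydrogen on a saturated chain carbon, three bonds along the chain from an oxygen on an unsaturated carbon. Among the compounds with values here, the only measured step that speaks to a change of this kind is the one from compound 1 to compound 3, where the alkyl chain was shortened: a 1.2-fold lower number from compound 1 to compound 3 (0.07 log units; within the scatter). Since that chain-length step lay within the scatter, a step of similar character is expected here as well, with no change in this assay beyond the scatter; the expected step is a 1.0-fold higher number from compound 2 to compound 4 (0.02 log units; within the scatter). Compound 4 is therefore estimated to give 70000 nM, with a range from 35000 nM to 140000 nM.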

Compound 4, half-maximal inhibitory concentration: 69000 nM
The estimate for compound 4 lay 1.0-fold (0.01 log units) above the measured number, within the range that was stated.
By their numbers in this assay, from the lowest: compounds 2, 4, 3 and 1 (each within the scatter of the next).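

In this assay, pentyl in place of hydrogen on a saturated chain carbon, three bonds along the chain from an oxygen on an unsaturated carbon, gives a 1.0-fold higher number from compound 2 to compound 4 (0.01 log units; within the scatter). The earlier chain step spoke only to the core shared by compound 1 and compound 3, so this result adds a second core on which a change in the alkyl chain leaves the number within the scatter. Nothing available accounts for this flat reading.

The compounds shown leave open whether an amine or a carboxylic acid at the end of this chain, or a longer chain on the core of compound 4, would move the number beyond the scatter. No pair shown differs in the saturated nitrogen ring alone, so the effect of its size also stays open.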